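Saturated phenylalkyl ester of the crown-ether alcohol

A few compounds are considered here, and "the series" means these few. Any claim that something is new, unique, unknown or untested is made for them only; others in the source may bear on it.

Measured compounds:
compound 1, `CC(C)=CC1C(C(=O)OCC2COCCOCCOCCOCCOCCO2)C1(C)C`, 40000 nM in a functional assay on HBL-100 cells (Homo sapiens) for inhibition, read by sulforhodamine B assay, with a stated time of 48 h; a higher number here means a weaker inhibitor of growth, a lower number a stronger inhibitor of growth
compound 2, `O=C(/C=C/c1ccccc1)OCC1COCCOCCOCCOCCOCCO1`, 57000 nM
compound 3, `CC/C=C/CC(=O)OCC1COCCOCCOCCOCCOCCO1`, > 100000 nM

Compound 3 stands at the floor of the set: its value in this assay is a limit of the assay, not a number (the limit of > 100000 nM in this assay, at which 1 of the 3 values shown sits). The two steps that lead into it are an at least 2.5-fold higher number from compound 1 to compound 3 (0.39 log units; beyond the scatter) and an at least 1.7-fold higher number from compound 2 to compound 3 (0.24 log units; that floor lies within the scatter). Compound 1 and compound 2 lie within the scatter of each other, a 1.4-fold higher number from compound 1 to compound 2 (0.15 log units; within the scatter).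

Compound 4, `O=C(CCCCc1ccccc1)OCC1COCCOCCOCCOCCOCCO1`, is not yet measured. It differs from compound 3 by 3-phenylpropyl in place of but-1-en-1-yl on a saturated chain carbon bound to a carbonyl carbon. Compound 2, which also carries a phenyl ring on the acyl side, and the step from compound 2 to compound 3 bear on this change; that step was at least modest but its floor lies within the scatter. Nothing here separates a phenyl ring on a saturated chain from one on a double bond. Compound 4 is therefore expected to stay near the limit or slightly below it, with an expected step of an at least 1.1-fold lower number from compound 3 to compound 4 (0.04 log units; that floor lies within the scatter), giving an estimate of 90000 nM with a range from 40000 nM to 200000 nM.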

Compound 4, concentration for 50% growth inhibition: 69000 nM
The estimate for compound 4 lay 1.3-fold (0.12 log units) above the measured number, within the range that was stated.
By their numbers in this assay, from the lowest: compounds 1, 2 and 4 (each within the scatter of the next). At a limit, above all of these: compound 3.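

Swapping but-1-en-1-yl for 3-phenylpropyl gives in this assay an at least 1.4-fold lower number from compound 3 to compound 4 (0.16 log units; that floor lies within the scatter) and so yields a measured number, but no step shown to exceed the scatter. Compound 3 itself remains a limit of the assay, not a number: the limit of > 100000 nM in this assay, at which 1 of the 4 values shown sits. On the carbonyl carbon, the data do not separate 4-phenylbutyl from 2-phenylethenyl, with a 1.2-fold higher number from compound 2 to compound 4 (0.08 log units; within the scatter) as the step, nor from 2,2-dimethyl-3-(2-methylprop-1-en-1-yl)cyclopropyl, with a 1.7-fold higher number from compound 1 to compound 4 (0.24 log units; within the scatter) as the step.

As far as these compounds go, it remains open whether an acyl group of any other kind could move the number beyond the scatter of compounds 1, 2 and 4. A longer chain ending in the phenyl ring, or an amine or a carboxylic acid on that chain, might show whether this position responds at all.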